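The source may hold more compounds than are shown below. What is called first, only, known or untested is meant among the compounds shown, and "the series" means these compounds.

Compound 3 `CO[C@@H]1CC=C2NN(c3cncnc3)C(=O)C[C@]2(C)O1` is measured in a functional assay on DU-145 cells (Homo sapiens) for inhibition, read by sulforhodamine B assay, with a stated time of 48 h (a lower number here means a stronger inhibitor, a higher number a weaker inhibitor), where compound 3 gives 17100 nM. Compound 1 `COc1ccc(N2NC3=CC[C@@H](OC)O[C@@]3(c3ccccc3)CC2=O)cc1` gives 10100 nM, a value within the scatter of compound 3, and compound 2 `CO[C@@H]1CC=C2NN(c3cc4ccccc4[nH]3)C(=O)C[C@]2(c2ccccc2)O1` gives 7900 nM, a number that lies beyond the scatter below compound 3. The only single-point step among these, a 1.3-fold lower number from compound 1 to compound 2 (0.11 log units; within the scatter), swaps the aryl group on the ring nitrogen and does not touch the ring carbon in question. Compound 4 `CO[C@@H]1CC=C2NN(c3cncnc3)C(=O)C[C@]2(c2ccccc2)O1` differs from compound 3 by phenyl in place of methyl on a saturated ring carbon. Going by the values given here, no measured step shows this change on an otherwise identical frame, so the expectation rests only on compounds 1 and 2, which carry phenyl there. Compound 4 is therefore expected to give 7500 nM, in a range of 2500 nM to 22000 nM, a step of a 2.3-fold lower number from compound 3 to compound 4 (0.36 log units; beyond the scatter).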

Compound 4, half-maximal inhibitory concentration: 7330 nM
For compound 4 the middle estimate is 1.0-fold (0.01 log units) above the measured one; the range from low to high includes it.
By their numbers in this assay, from the lowest: compounds 4, 2, 1 and 3 (each within the scatter of the next, the first and the last beyond it).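

In this assay, the swap of methyl for phenyl on this saturated ring carbon can now be read directly on one frame, and it gives a 2.3-fold lower number from compound 3 to compound 4 (0.37 log units; beyond the scatter) as a modest step. With phenyl in place, the group on the ring nitrogen shows no clear effect among these compounds: the readings are a 1.1-fold lower number from compound 2 to compound 4 (0.03 log units; within the scatter) and a 1.4-fold lower number from compound 1 to compound 4 (0.14 log units; within the scatter). Nothing measured here explains the phenyl step. Still open, as far as these compounds go, is how an ethyl chain, a benzyl group or a phenyl bearing an amine would behave on this carbon. Also open, from the compounds shown here alone, is whether the phenyl step keeps its size with other groups on the ring nitrogen.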